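Replacing hydroxy with bromo: compound 3 to compound 4

The source may hold more compounds than are shown below. What is called first, only, known or untested is meant among the compounds shown, and "the series" means these compounds.

Values in an ADME assay on HEK293 cells (Homo sapiens) for cytotoxicity, read by CellTiter-Glo and resazurin assay, with a stated time of 72 h (a higher number here means that more compound is needed for the effect, a lower number that less compound is needed), each of them a limit:
Compound 1 `CC(C)N(Cc1cccc(OCCCCCC(=O)O)c1)C(=O)c1ccc(-c2ccco2)cc1`: > 26000 nM
Compound 2 `COc1cc(OC)cc(-c2ccc(C(=O)N(Cc3cccc(OCCCCCC(=O)O)c3)C(C)C)cc2)c1`: > 26000 nM
Compound 3 `CC(C)N(Cc1cccc(OCCCCCC(=O)O)c1)C(=O)c1ccc(-c2cccc(O)c2)cc1`: > 26000 nM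

Compound 3 stands on (the limit of > 26000 nM in this assay, at which 3 of the 3 values shown sit). Compound 4 `CC(C)N(Cc1cccc(OCCCCCC(=O)O)c1)C(=O)c1ccc(-c2cccc(Br)c2)cc1` differs from it as follows: bromo in place of hydroxy on an aromatic carbon. This puts bromo in place of hydroxy on an aromatic carbon, turning 3-hydroxyphenyl into 3-bromophenyl. The measured steps bearing on this change are a step that the two limits leave unreadable from compound 1 to compound 3 and a step that the two limits leave unreadable from compound 2 to compound 3. Neither gives a size, so the expectation rests on compound 3 and its limit of > 26000 nM. In this assay, no change beyond the scatter is expected, and the estimated step is a step that the limit leaves unreadable from compound 3 to compound 4. For compound 4 the estimate is 30000 nM, with an expected range from 15000 nM to 60000 nM.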

Compound 4, half-maximal effective concentration: > 26000 nM
Compound 4: no number, only a limit; the forecaster's own chance of this, stated with the estimate: 85%; the middle value is on the limit's open side.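

Compound 4 gives only a limit in this assay, so no step between it and compound 1, compound 2 or compound 3 can be read: the limit of > 26000 nM in this assay, at which 4 of the 4 values shown sit.

The compounds shown leave open whether the groups exchanged on the shared core make any difference in this assay.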